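Swapping an ether oxygen out of a quinoline side chain

This account rests on a few compounds, and the source may have more. Where it says the series, first, only, none or still open, it means among the compounds named here.

Compound 1 `O=c1c(-c2nn[nH]n2)c[nH]c2c(F)ccc(F)c12` gives > 0.156 mg/kg in a functional assay on the whole organism (strain Sprague-Dawley) for inhibition, with Rattus norvegicus as the target (on this read-out higher numbers stand for an effect only at larger amounts of compound and lower numbers for an effect already at smaller amounts), a limit of the assay rather than a number.
Compound 2 `Fc1ccc2ncc(-c3nn[nH]n3)cc2c1` gives < 25 mg/kg in this assay, again a limit and not a number.
Compound 3 `c1cc2ncc(-c3nn[nH]n3)cc2cc1OC1CCCCC1` gives 5 mg/kg in this assay.

Going by the values given here, compound 3 therefore stands as the only compound with a firm number; the two others sit at limits. Among the compounds with values here, the single step between measured compounds, a step that the limit leaves unreadable from compound 2 to compound 3, cannot be sized because the limit of < 25 mg/kg in this assay, at which 1 of the 3 values shown sits, marks where compound 2 sits. Compound 4 `c1nc2ccc(C3CCCCC3)cc2cc1-c1nn[nH]n1` differs from compound 3 by cyclohexyl in place of cyclohexyloxy on an aromatic carbon. Within the data shown here, no measured step shows what removing the oxygen from this side chain does, so there is no basis to expect a shift beyond the usual scatter in this assay in either direction. Compound 4 is therefore estimated at about 5 mg/kg, with a plausible range from 1.25 mg/kg to 20 mg/kg, which amounts to an expected step of no change at the digits printed from compound 3 to compound 4 (within the scatter).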

Compound 4, minimum effective dose: 5 mg/kg
For compound 4 middle estimate and measured number coincide at the digits printed; the measured number falls inside the stated range.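

Putting cyclohexyl in place of cyclohexyloxy on this aromatic carbon gives no change at the digits printed from compound 3 to compound 4 (within the scatter) in this assay. Going by these compounds alone, this is the first step at this position that can be read, and it involves only the loss of the ether oxygen, since the six-membered carbon ring stays in both side chains. At this position, then, the ether oxygen can go without a change that shows in this whole-organism read-out, although this rests on a single pair of compounds and sets no rule for other side chains.

From the compounds shown here alone, compound 2, with fluoro at this place, stands at a limit and not a number, so the steps from it cannot be read, because their size is hidden: the limit of < 25 mg/kg in this assay, at which 1 of the 4 values shown sits. What an amine, a carboxylic acid or a longer chain on this aromatic carbon would do in this assay remains open.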